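The source may hold more compounds than are shown below. What is called first, only, known or untested is meant among the compounds shown, and "the series" means these compounds.

All three measured compounds were tested in a functional assay on XF498 cells (Homo sapiens) for cytotoxicity; on this read-out lower numbers stand for an effect already at smaller amounts and higher numbers for an effect only at larger amounts of compound:

Compound 1, `C=CCCCCCCCC#CC#CC(O)CC(C)=O`, gives 4.45 ug/mL.
Compound 2, `C=CCCCCCCCC#CC#CCO`, gives 5.26 ug/mL.
Compound 3, `C=CCCCCCCCC#CC#CCOCC(=O)O`, gives 4.96 ug/mL.

The three numbers sit close together. The step of a 1.1-fold lower number from compound 2 to compound 3 (0.03 log units; within the scatter) and the step of a 1.1-fold higher number from compound 1 to compound 3 (0.05 log units; within the scatter) are both within the scatter, as is the step of a 1.2-fold higher number from compound 1 to compound 2 (0.07 log units; within the scatter), so none of the three compounds can be set apart from the others on this read-out.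

Compound 4, `CCCCCCCC#CC#CCOCC(=O)O`, differs from compound 3 at the far end of the chain: hydrogen in place of vinyl on a saturated chain carbon, seven bonds along the chain from a triple-bonded carbon. For the measured compounds named here, no measured step touches this end of the molecule; every step seen so far alters the other end, around the oxygen on the saturated carbon and the triple-bonded carbon, and each of those steps stayed within the scatter. Going by the values given here, there is thus no direct precedent, and the change is small. A step no larger than the scatter is expected for compound 4, that is a 1.0-fold higher number from compound 3 to compound 4 (0.00 log units; within the scatter), with the number estimated at 5 ug/mL and a range from 2.5 ug/mL to 10 ug/mL.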

Compound 4, concentration for half-maximal effect: 7.72 ug/mL
Compound 4: the middle estimate sits 1.5-fold (0.19 log units) below what was measured; low and high end bracket the measured number.
By their numbers in this assay, from the lowest: compounds 1, 3, 2 and 4 (each within the scatter of the next).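

In this assay, for the compounds shown here, this is the first change at this position, on a saturated chain carbon, seven bonds along the chain from a triple-bonded carbon: hydrogen in place of vinyl gives a 1.6-fold higher number from compound 3 to compound 4 (0.19 log units; within the scatter). Like the changes at the other end of the molecule, this one stays within the scatter, so the vinyl group is not shown to matter for this read-out. Nothing available here bears on the reason for this result.

Only this one change at this position is shown, so it remains open whether an amine, a phenyl ring or a longer chain there would give a step beyond the scatter. On these data alone, it also remains open whether the same change would stay within the scatter on the other ends of the molecule, such as that of compound 1.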